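The source may report more compounds than this note shows. Statements on the series, on what has been measured and on what is new or still open speak of the compounds shown alone.

Working notes on the aryl series. Compound 1 `Clc1ccc(CO/N=C/c2c(-c3cccc4ccccc34)nc3sccn23)cc1Cl` carries naphthalen-1-yl on the shared core; in an assay on HepG2 cells for agonist activity at nuclear receptor subfamily 1 group I member 3 (Homo sapiens), read by a luciferase reporter, with a stated time of 23 h (a lower number here means that less compound is needed, a higher number that more compound is needed for the effect), compound 1 gives 940 nM. Compound 2 `CC(C)c1ccc(-c2nc3sccn3c2/C=N/OCc2ccc(Cl)c(Cl)c2)cc1` has 4-isopropylphenyl there, and in this assay compound 2 gives 590 nM. Compound 3 `COc1ccc(-c2nc3sccn3c2/C=N/OCc2ccc(Cl)c(Cl)c2)cc1` has 4-methoxyphenyl, and in this assay compound 3 gives 490 nM, the lowest of the three numbers, though none of the three is separated from another beyond the scatter: a 1.6-fold lower number from compound 1 to compound 2 (0.20 log units; within the scatter), a 1.9-fold lower number from compound 1 to compound 3 (0.28 log units; within the scatter), and a 1.2-fold lower number from compound 2 to compound 3 (0.08 log units; within the scatter).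

Compound 4 `CC(C)(C)c1ccc(-c2nc3sccn3c2/C=N/OCc2ccc(Cl)c(Cl)c2)cc1` differs from compound 3 by tert-butyl in place of methoxy on an aromatic carbon. Within the data shown here, the step that bears on this is the one between compound 2 and compound 3, an exchange of one small aryl substituent for another that moved the number only within the scatter; the steps from compound 1 point the same way, all small. Tert-butyl is a branched alkyl like isopropyl, so a number near that of compound 2 is expected, and no step beyond the scatter is expected in this assay: a 1.3-fold higher number from compound 3 to compound 4 (0.12 log units; within the scatter). The estimate for compound 4 in this assay is therefore 650 nM, with a range of 300 nM to 1400 nM.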

Compound 4, half-maximal effective concentration: 2400 nM
For compound 4 the middle estimate is 3.7-fold (0.57 log units) below the measured one, outside the stated range (above it).
By their numbers in this assay, from the lowest: compounds 3, 2 and 1 (each within the scatter of the next); then compound 4.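

Among these compounds, the aryl substituent is less forgiving than the first three compounds suggested: in this assay tert-butyl in place of methoxy brings a 4.9-fold higher number from compound 3 to compound 4 (0.69 log units; beyond the scatter) and the single added methyl on the isopropyl group brings a 4.1-fold higher number from compound 2 to compound 4 (0.61 log units; beyond the scatter) in the first steps to pass the scatter. 4-(tert-Butyl)phenyl in place of naphthalen-1-yl likewise brings a 2.6-fold higher number from compound 1 to compound 4 (0.41 log units; beyond the scatter) and so sets this group apart from all three other aryl groups, which stay within the scatter of one another. Nothing at hand gives a cause for this rise.

Going by these compounds, whether the rise is particular to tert-butyl or extends to a cyclopropyl or trifluoromethyl group on the same carbon stays open. Also open, on these data alone, is how this assay would respond to an amine or a carboxylic acid at that carbon, and whether the step holds with another group in place of the dichlorophenyl end shared by all four compounds.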